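From ethyl to methoxy on compound 2

This account rests on a few compounds, and the source may have more. Where it says the series, first, only, none or still open, it means among the compounds named here.

Measured so far in a physicochemical assay for solubility, in phosphate buffer, measured as kinetic solubility, with a stated time of 24 h, at pH 6.5; a higher number here means a more soluble compound, a lower number a less soluble compound:
- Compound 1 `CC(C)Oc1cc(Oc2ccc(S(C)(=O)=O)cc2)cc(-c2cccc(=O)[nH]2)c1`: 11000 nM
- Compound 2 `CCc1cnc(-c2cc(Oc3ccc(S(C)(=O)=O)cc3)cc(OC(C)C)c2)[nH]c1=O`: 5700 nM

Among the measured compounds shown here, only these two numbers are available, and they cannot be told apart: compound 2 stands at 5700 nM, and the one measured step, a 1.9-fold lower number from compound 1 to compound 2 (0.29 log units; within the scatter), stays within the scatter of repeated measurements.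

Compound 3 `COc1cnc(-c2cc(Oc3ccc(S(C)(=O)=O)cc3)cc(OC(C)C)c2)[nH]c1=O` keeps the rest of compound 2 and changes a single group, with methoxy in place of ethyl on an aromatic carbon. For the measured compounds named here, no measured step isolates this swap. The step of a 1.9-fold lower number from compound 1 to compound 2 (0.29 log units; within the scatter) exchanged the whole ring group that carries the ethyl, so it bears on the question only indirectly. Even that larger exchange did not move this assay beyond the scatter, so a step beyond the scatter is not expected here, in either direction.

The estimated step is a 1.1-fold higher number from compound 2 to compound 3 (0.06 log units; within the scatter). For compound 3 the expected value is 6500 nM, with an estimated range from 2800 nM to 15000 nM.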

Compound 3, solubility: 7100 nM
The estimate for compound 3 lay 1.1-fold (0.04 log units) below the measured number; measured number inside the range.
By their numbers in this assay, from the lowest: compounds 2, 3 and 1 (each within the scatter of the next).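

In this assay, among the compounds shown here, this is the first step that isolates the position on the ring with 2 nitrogen, and methoxy in place of ethyl gives a 1.2-fold higher number from compound 2 to compound 3 (0.10 log units; within the scatter). The two groups have the same number of heavy atoms and differ in that methoxy carries 1 hydrogen-bond acceptor and ethyl carries none, yet this difference leaves compound 2 and compound 3 indistinguishable in this read-out. The larger exchange of the whole ring group, now with methoxy on it, gives a 1.5-fold lower number from compound 1 to compound 3 (0.19 log units; within the scatter), so the three compounds cannot be told apart, and nothing measured here offers a reason for this.

Ethyl and methoxy are both small groups, so it remains open whether an amine, a carboxylic acid or a longer chain such as butyl at this same position would move the number beyond the usual scatter. Also open is how the swap from ethyl to methoxy would read in any measurement other than this assay, as the numbers shown here come from that one alone.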